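This account rests on a few compounds, and the source may have more. Where it says the series, first, only, none or still open, it means among the compounds named here.

Two compounds built on the same core have been examined in an ADME assay on HepG2 2.2.15 cells (Homo sapiens) for cytotoxicity; on this read-out higher numbers stand for lower toxicity in this test and lower numbers for higher toxicity in this test. Compound 1 `Cn1c(=O)c(CCO)c(-c2ccccc2Cl)c2cc(Cl)ccc21` gives 34000 nM in this assay. Compound 2 `CCCCCCCC(=O)OCCc1c(-c2ccccc2Cl)c2cc(Cl)ccc2[nH]c1=O` gives 78000 nM in this assay, the higher of the two numbers; compound 1 sits lower, and the gap between the two lies beyond the usual scatter. The two compounds differ from each other in more than one place, so their numbers alone do not show which change carries the difference.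

Compound 3 `CC12CCC(C(=O)OCCc3c(-c4ccccc4Cl)c4cc(Cl)ccc4[nH]c3=O)(OC1=O)C2(C)C` has not yet been measured. It differs from compound 2 in a single place, on a carbonyl carbon whose other neighbours are an oxygen next to a carbonyl group: a group of 11 heavy atoms (9 carbon, 2 oxygen; one five-membered non-aromatic ring of carbon only, one five-membered non-aromatic ring with 1 hetero atom) in place of a group of 7 heavy atoms (7 carbon; no ring), on a carbonyl carbon The heptyl leaves, and a group of 11 heavy atoms with one five-membered non-aromatic ring of carbon only and one five-membered non-aromatic ring with one hetero atom enters.

Going by the values given here, no measured step covers a change of this kind. With both measured numbers lying in a similar band, the step from compound 2 to compound 3 is expected to be small, a 1.3-fold lower number from compound 2 to compound 3 (0.11 log units; within the scatter), and not beyond the scatter. Compound 3 is therefore estimated at 60000 nM in this assay, within a range from 25000 nM to 140000 nM.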

Compound 3, half-maximal cytotoxic concentration: > 1800000 nM
Compound 3 was reported as a limit; the forecaster's own chance of this, stated with the estimate: 20%; middle value at least 30-fold (1.47 log units) away from the limit.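

In this assay, the place on the carbonyl carbon proves far from neutral: putting the group of 11 heavy atoms, with its two five-membered non-aromatic rings, in place of the heptyl gives an at least 23-fold higher number from compound 2 to compound 3 (1.36 log units; beyond the scatter), a large step and the only single-place change shown on this core. For compound 3 the reading is a limit of the assay and not a number: the limit of > 1800000 nM in this assay, at which 1 of the 3 values shown sits. Compound 1 and compound 2 differ in more than one place and could isolate no single change, whereas this step shows that the group on this carbonyl carbon alone can move the read-out well beyond the scatter, towards lower toxicity in this test.

The entering group brings two rings and two hydrogen-bond acceptors in one change, and the compounds shown do not separate these features from each other. Going by these compounds, it stays open whether a shorter chain such as butyl, or a single cyclopentyl ring of carbon only, on the same carbonyl carbon would sit nearer compound 2 or nearer compound 3, and how far the true figure for compound 3 lies past its limit.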